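The source may hold more compounds than are shown below. What is called first, only, known or untested is meant among the compounds shown, and "the series" means these compounds.

Compound 1 `COc1cc(OC)c(C(=O)/C=C/c2ccccc2SC)c(OC)c1` and compound 2 `COc1cc(OC)c(C(=O)/C=C/c2ccc(Cl)cc2)c(OC)c1` share one core and differ only in the aryl group on the double-bonded chain carbon. In a functional assay on HaCaT cells (Homo sapiens), read by fluorescence and BrdU incorporation, with a stated time of 48 h, tested at 10 uM (on this read-out lower numbers stand for a stronger effect and higher numbers for a weaker effect at the one concentration tested), compound 1 gives 24%, and compound 2 gives 26%. Among the compounds with values here, the one measured step, a number 2 percentage points higher from compound 1 to compound 2 (within the scatter), exchanges 2-(methylsulfanyl)phenyl for 4-chlorophenyl. Within the data shown here, compound 2 stands at the highest of the two numbers so far, with compound 1 separated from it by a gap within the scatter, so nothing can be read from that difference. Compound 3 `COc1cc(OC)c(C(=O)/C=C/c2ccc(Br)cc2)c(OC)c1` has not yet been measured; it differs from compound 2 by bromo in place of chloro on an aromatic carbon. Among the measured compounds shown here, no measured step swaps one halogen for another. For the measured compounds named here, the only step available shows that a considerably larger exchange at the same aryl position left the read-out unchanged within the scatter, and a step no larger than the scatter is therefore expected here, namely a number 1 percentage points lower from compound 2 to compound 3 (within the scatter). Compound 3 is estimated at 25% in this assay, within a range from 12% to 40%.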

Compound 3, a percentage reported as activity, at one concentration (the size of the read-out at that concentration, not a potency): 24%
The estimate for compound 3 lay 1 percentage points above the measured number, and the stated range covers the measured number.
By their numbers in this assay, from the lowest: compounds 1, 3 and 2 (each within the scatter of the next).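

In this assay, exchanging chloro for bromo on an aromatic carbon para to a large group gives a number 2 percentage points lower from compound 2 to compound 3 (within the scatter), so the read-out does not separate these two halogens at this place. The wider exchange of the whole aryl group, 2-(methylsulfanyl)phenyl for 4-bromophenyl, gives no change at the digits printed from compound 1 to compound 3 (within the scatter), and so a second, different aryl exchange also stays within the scatter, whichever halogen the 4-halophenyl group carries. No measurement is at hand that would account for this level read-out.

The compounds shown leave open whether a group of another kind on this aryl ring, such as an amine or a carboxylic acid, would move the number beyond the scatter. They also leave open whether changes to the shared core, outside this aryl group, would do so.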